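Trimming the Pyrrolidinylmethyl Group Down to a Methyl

The source may hold more compounds than are shown below. What is called first, only, known or untested is meant among the compounds shown, and "the series" means these compounds.

Two compounds share a core that carries an aryl urea on one side and an anilino group on the other. Compound 1, `COc1ccc(Nc2ncnc3ccc(NC(=O)Nc4ccc(CN5CCN(C)CC5)cc4)cc23)cc1Cl`, and compound 2, `O=C(Nc1ccc(CN2CCCC2)cc1)Nc1ccc2ncnc(Nc3cccc(C(F)(F)F)c3)c2c1`, were tested in a functional assay on A-431 cells (Homo sapiens) for antiproliferative activity, read by MTT assay, with a stated time of 72 h; on this read-out higher numbers stand for weaker inhibition and lower numbers for stronger inhibition. Compound 1 gives 2010 nM, and compound 2 gives 1360 nM. Compound 2 has the lowest of these two numbers, but its gap to compound 1 lies within the usual scatter, so the two cannot be told apart on this evidence.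

Compound 3, `Cc1ccc(NC(=O)Nc2ccc3ncnc(Nc4cccc(C(F)(F)F)c4)c3c2)cc1`, has not yet been measured. It differs from compound 2 in one place: hydrogen in place of pyrrolidin-1-yl on a saturated chain carbon bound to an aromatic carbon. Within the data shown here, no measured pair shows what this kind of change does here, so the expectation rests on compound 2 alone. A modest drift toward a higher number, meaning weaker inhibition, seems somewhat more likely than a gain, yet a step in either direction beyond the scatter cannot be ruled out. Compound 3 is therefore expected to come in near 2500 nM, within a range from 800 nM to 8000 nM. The step of a 1.8-fold higher number from compound 2 to compound 3 (0.26 log units; within the scatter) in this assay is estimated to be small and toward weaker inhibition.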

Compound 3, half-maximal inhibitory concentration: > 10000 nM
Compound 3: a limit, no number (the forecaster's own chance of this, stated with the estimate: 10%); at least 4.0-fold (0.60 log units) between middle value and limit.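

In this assay, compound 3 gives > 10000 nM, which is a limit of the assay and not a number. Replacing pyrrolidin-1-yl with hydrogen on a saturated chain carbon bound to an aromatic carbon brings an at least 7.3-fold higher number from compound 2 to compound 3 (0.86 log units; beyond the scatter), the first step measured at this place, and it shows that the antiproliferative effect of compound 2 on these cells is sensitive to what this carbon carries. On these data alone, the true size of the step stays unknown, because the reading stops at the limit of the assay: the limit of > 10000 nM in this assay, at which 1 of the 3 values shown sits.

The compounds shown do not tell whether the pyrrolidin-1-yl ring itself matters or whether another group on the same carbon would serve as well, such as a dimethylamino group, a morpholin-4-yl ring or a plain hydroxyl, and those three would begin to separate a need for an amine from a need for any group at all. Compound 1 differs from compound 2 in more than one place, so it cannot settle this question.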